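The source may report more compounds than this note shows. Statements on the series, on what has been measured and on what is new or still open speak of the compounds shown alone.

Notes on the series around the core of compound 1 `C#CCCCOc1ccc2oc(=O)c(C(=O)OC)cc2c1`. Two companions carry an alkyne ether: compound 3 `C#CCCCCOc1ccc2c(C)cc(=O)oc2c1` gives 59.9 nM in an assay on cells for inhibition of Amine oxidase [flavin-containing] A (Homo sapiens), read by Amplex Red, with stated times of 30 min and 45 min (on this read-out lower numbers stand for stronger inhibition and higher numbers for weaker inhibition), and compound 2 `C#CCCCOc1ccc2cc(NC(C)=O)c(=O)oc2c1` gives 930 nM in this assay. Compound 1 is reported only as > 10000 nM, a limit of this assay and not a number, standing at the limit of > 10000 nM in this assay, at which 1 of the 3 values shown sits. The unmeasured compound 4 `COC(=O)c1cc2cc(OCCc3ccc(Cl)cc3)ccc2oc1=O` keeps the core of compound 1 and alters the ether chain: 4-chlorophenyl in place of propargyl on a saturated chain carbon, two bonds along the chain from an oxygen on an aromatic ring. For the measured compounds named here, no measured pair with a single change is at hand, so the step cannot be read from a neighbour; with the start at a limit only a gain can be resolved, and a modest one is expected, an at least 1.6-fold lower number from compound 1 to compound 4 (0.22 log units; that floor lies within the scatter). Compound 4 is therefore estimated at 6000 nM, with a range from 1500 nM to 20000 nM.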

Compound 4, half-maximal inhibitory concentration: > 10000 nM
Compound 4 ended at the assay's limit; the forecaster's own chance of this, stated with the estimate: 45%; at least 1.6-fold (0.22 log units) between middle value and limit.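

Compound 1 and compound 4 both stand at a limit of this assay, so no step can be read between them: the limit of > 10000 nM in this assay, at which 2 of the 4 values shown sit. The compounds shown leave open whether any ether chain on the core of compound 1 gives a readable value in this assay.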